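Methoxy in place of chloro: compound 3 to compound 4

The source may hold more compounds than are shown below. What is called first, only, known or untested is meant among the compounds shown, and "the series" means these compounds.

In a functional assay on K562 cells (Homo sapiens) for antiproliferative activity, read by MTT assay, with a stated time of 48 h (a lower number here means a stronger inhibitor, a higher number a weaker inhibitor), compound 1 `COc1ccc(-c2ccc3c(c2)C(=O)C(=O)N3)cc1`, which keeps the amide hydrogen, gives 6920 nM. Compound 2 `COc1ccc(-c2ccc3c(c2)C(=O)C(=O)N3Cc2ccc(Cl)cc2)cc1`, with 4-chlorobenzyl in place of that hydrogen, gives 350 nM, and compound 3 `COc1ccc(-c2ccc3c(c2)C(=O)C(=O)N3Cc2cccc(Cl)c2)cc1`, with 3-chlorobenzyl there, gives 200 nM. Both benzyl compounds mark large steps: a 20-fold lower number from compound 1 to compound 2 (1.30 log units; beyond the scatter) and a 35-fold lower number from compound 1 to compound 3 (1.54 log units; beyond the scatter). Compound 3 thus stands far from compound 1 but level with compound 2, as a 1.8-fold lower number from compound 2 to compound 3 (0.24 log units; within the scatter) shows.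

Compound 4 `COc1ccc(-c2ccc3c(c2)C(=O)C(=O)N3Cc2cccc(OC)c2)cc1` keeps the benzyl group and carries 3-methoxybenzyl: methoxy in place of chloro on an aromatic carbon, (methoxy in place of chloro on an aromatic carbon). Among the measured compounds shown here, no measured step exchanges chloro for another group, so the data hold no direct precedent. The two large steps concern adding the benzyl group as a whole, which compound 4 retains, so they offer no reason to expect a large change. The closest guide is the move of the chloro group between compound 2 and compound 3, a 1.8-fold lower number from compound 2 to compound 3 (0.24 log units; within the scatter), which stayed within the scatter. A small shift towards a higher number is therefore expected, probably within the scatter, and the estimated step is a 1.5-fold higher number from compound 3 to compound 4 (0.18 log units; within the scatter). Compound 4 is expected at 300 nM, with an estimated range from 120 nM to 800 nM.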

Compound 4, half-maximal inhibitory concentration: 680 nM
Estimate against measurement, compound 4: 2.3-fold (0.36 log units) below; the measured number falls inside the stated range.
By their numbers in this assay, from the lowest: compounds 3, 2 and 4 (each within the scatter of the next, the first and the last beyond it); then compound 1.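

At the aromatic carbon that carries chloro in compound 3, the identity of the group matters in this assay: the exchange for methoxy gives a step beyond the scatter (a 3.4-fold higher number from compound 3 to compound 4 (0.53 log units; beyond the scatter)), whereas the earlier move of chloro around the ring did not. The exchange does not undo the gain from the benzyl group, since compound 4 stays level with the 4-chlorobenzyl compound (a 1.9-fold higher number from compound 2 to compound 4 (0.29 log units; within the scatter)) and remains far from the compound that keeps the amide hydrogen (a 10-fold lower number from compound 1 to compound 4 (1.01 log units; beyond the scatter)), so most of the effect still rests with the substituted benzyl group as a whole in all three benzyl compounds. No measurement is at hand that would account for the step from chloro to methoxy.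

The compounds shown leave open whether that step is particular to methoxy or would extend to other groups on this carbon, such as fluoro, hydroxy, an amine or a carboxylic acid. They also do not tell whether the same exchange would give a step of like size in compound 2, or how a longer chain in place of the benzyl group on the amide-type nitrogen would read in this assay.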